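This account rests on a few compounds, and the source may have more. Where it says the series, first, only, none or still open, it means among the compounds named here.

Measured so far in a functional assay on BT-474 cells (Homo sapiens) for cytotoxicity, with a stated time of 72 h (a higher number here means a weaker inhibitor, a lower number a stronger inhibitor), for the series
- compound 1 `Oc1ccc(CNC2(c3ccccc3F)CCCC2)cc1CN1CCN(Cc2ccccc2)CC1` gives 34700 nM
- compound 2 `Fc1ccccc1C1(NCc2cccc(CN3CCCCC3)c2)CCCC1` gives 40000 nM
- compound 3 `CN1CCC(Cc2cccc(CNC3(c4ccccc4F)CCCC3)c2)CC1` gives 15500 nM

Compound 3 has the lowest of the three numbers at 15500 nM in this assay and is the best of this small set, with compound 1 and compound 2 both higher by more than the scatter. Next is compound 4 `CN1CCC(Cc2cccc(CNC3(c4ccc(F)cc4)CCCC3)c2)CC1` with the change 4-fluorophenyl in place of 2-fluorophenyl on a saturated ring carbon as its only difference from compound 3, namely 4-fluorophenyl in place of 2-fluorophenyl on a saturated ring carbon.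

For the measured compounds named here, all three measured compounds carry the 2-fluorophenyl, so no measured step bears directly on this change. Going by the values given here, the only step available, a 2.6-fold lower number from compound 2 to compound 3 (0.41 log units; beyond the scatter), is modest and concerns a different group. With nothing to set a direction, the expected step is a 1.0-fold higher number from compound 3 to compound 4 (0.01 log units; within the scatter) and no shift beyond the scatter is expected. For compound 4 the estimated value is 16000 nM with an expected range of 7500 nM to 34000 nM in this assay.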

Compound 4, half-maximal inhibitory concentration: 2100 nM
The estimate for compound 4 lay 7.6-fold (0.88 log units) above the measured number; the whole stated range lies above it.
By their numbers in this assay, from the lowest: compound 4; then compound 3; then compounds 1 and 2 (each within the scatter of the next).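

In this assay, 4-fluorophenyl in place of 2-fluorophenyl on a saturated ring carbon gives a 7.4-fold lower number from compound 3 to compound 4 (0.87 log units; beyond the scatter). The two compounds have the same atoms joined differently, so this step shows that the read-out depends on where the fluorine sits on the phenyl ring, which could not be seen while every measured compound carried 2-fluorophenyl. Nothing available explains the size or direction of this step.

The compounds shown leave open whether a plain phenyl or a chlorophenyl at this saturated ring carbon would give a lower or higher number than 4-fluorophenyl. They also leave open whether the same change would give a similar step with the piperidin-1-yl group of compound 2 or the benzylpiperazine-bearing phenol of compound 1.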